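A few compounds are considered here, and "the series" means these few. Any claim that something is new, unique, unknown or untested is made for them only; others in the source may bear on it.

In a functional assay on PC-3 cells (Homo sapiens) for inhibition, read by WST assay, with a stated time of 48 h (a lower number here means a stronger inhibitor of growth, a higher number a weaker inhibitor of growth), compound 1 `C=C(C)C(=O)N(Cc1cccc(Br)c1)C(=O)/C=C/c1cc(OC)c(OC)c(OC)c1` gives > 10000 nM, a limit of the assay. Compound 2 `C=C(C)C(=O)N(Cc1ccccc1C)C(=O)/C=C/c1cc(OC)c(OC)c(OC)c1` gives > 10000 nM, also a limit. Going by the values given here, compound 3 `C#CCN(C(=O)/C=C/c1cc(OC)c(OC)c(OC)c1)C(=O)C(=C)C` gives 7300 nM, the only actual number of the three. Compound 4 `C=C(C)C(=O)NC(=O)/C=C/c1cc(OC)c(OC)c(OC)c1` carries hydrogen in place of propargyl on an amide-type nitrogen. The measured steps nearest to this change, an at least 1.3-fold lower number from compound 1 to compound 3 (0.13 log units; that floor lies within the scatter) and an at least 1.3-fold lower number from compound 2 to compound 3 (0.13 log units; that floor lies within the scatter), swap the group on that nitrogen, and their floors lie within the scatter. None of the three measured compounds carries hydrogen there, so these steps give no firm size or direction. The expected result is a 1.2-fold higher number from compound 3 to compound 4 (0.09 log units; within the scatter), with no change expected beyond the scatter in this assay. For compound 4 the estimated value is 9000 nM, within an expected range of 3500 nM to 20000 nM.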

Compound 4, concentration for 50% growth inhibition: 8200 nM
Estimate against measurement, compound 4: 1.1-fold (0.04 log units) above; the range from low to high includes it.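

In this assay, hydrogen on this amide-type nitrogen gives a result within the scatter of propargyl, with a 1.1-fold higher number from compound 3 to compound 4 (0.05 log units; within the scatter), so propargyl is not needed there to keep this level of growth inhibition. The comparisons with the benzyl-type groups give an at least 1.2-fold lower number from compound 2 to compound 4 (0.08 log units; that floor lies within the scatter) and an at least 1.2-fold lower number from compound 1 to compound 4 (0.08 log units; that floor lies within the scatter). Both are floors within the scatter, because those two compounds each stand at a limit: the limit of > 10000 nM in this assay, at which 2 of the 4 values shown sit.

From the compounds shown here alone, how far compound 1 and compound 2 truly lie from compound 4 stays open. So does whether a methyl group, a longer alkyl chain or a chain bearing an amine on this nitrogen would move the number beyond the scatter.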